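Swapping 4-fluorophenyl for 3-methoxyphenyl: what to expect

This account rests on a few compounds, and the source may have more. Where it says the series, first, only, none or still open, it means among the compounds named here.

Three compounds have been measured so far in a functional assay on the whole organism (strain Kunming) with Mus musculus as the target, with a stated time of 0.5 h (on this read-out higher numbers stand for an effect only at larger amounts of compound and lower numbers for an effect already at smaller amounts), with these results:

- compound 1 `COc1cc(OC)c(OC)cc1/C=C/COC(=O)/C=C/c1ccc(OC)c(OC)c1` gives 58.1 mg/kg in this test
- compound 2 `COc1cc(OC)c(OC)cc1/C=C/COC(=O)/C=C/c1ccccc1Cl` gives 58.7 mg/kg in this test
- compound 3 `COc1cc(OC)c(OC)cc1/C=C/COC(=O)/C=C/c1ccc(F)cc1` gives 34.6 mg/kg in this test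

Among the compounds with values here, compound 3 stands level with the other two, as no step among the three leaves the usual scatter of repeated measurements. Compound 4 `COc1cccc(/C=C/C(=O)OC/C=C/c2cc(OC)c(OC)cc2OC)c1` differs from compound 3 in one group. Its change is 3-methoxyphenyl in place of 4-fluorophenyl on a double-bonded chain carbon bound to a double-bonded chain carbon with 3-methoxyphenyl in place of 4-fluorophenyl on a double-bonded chain carbon bound to a double-bonded chain carbon.

Within the data shown here, no measured compound carries 3-methoxyphenyl, so the evidence is indirect. Three steps at this same place bear on the swap, and all were small: a 1.7-fold lower number from compound 1 to compound 3 (0.23 log units; within the scatter) and a 1.7-fold lower number from compound 2 to compound 3 (0.23 log units; within the scatter) and also a 1.0-fold higher number from compound 1 to compound 2 (0.00 log units; within the scatter) were seen. Compound 1 is the closest guide, since its 3,4-dimethoxyphenyl group also carries methoxy, and its 58.1 mg/kg pulls the expectation a little towards its number. No step beyond the scatter is therefore expected in this assay for this swap.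

The expected change is a 1.4-fold higher number from compound 3 to compound 4 (0.14 log units; within the scatter) on this estimate. For compound 4 the estimated value is 48 mg/kg with an expected range from 25 mg/kg to 90 mg/kg in this test.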

Compound 4, dose for half-maximal effect: 72.9 mg/kg
Compound 4: the middle estimate sits 1.5-fold (0.18 log units) below what was measured; the measured number falls inside the stated range.
By their numbers in this assay, from the lowest: compounds 3, 1, 2 and 4 (each within the scatter of the next, the first and the last beyond it).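

In this assay, within the data shown here, the step of a 2.1-fold higher number from compound 3 to compound 4 (0.32 log units; beyond the scatter) is the first at this position to leave the usual scatter, so the group on this double-bonded chain carbon can now be seen to matter, though only modestly and, so far, only between 4-fluorophenyl and 3-methoxyphenyl. The other two new steps stay within the scatter: one is a 1.2-fold higher number from compound 2 to compound 4 (0.09 log units; within the scatter) and the other, with hydrogen in place of methoxy on an aromatic carbon, is a 1.3-fold higher number from compound 1 to compound 4 (0.10 log units; within the scatter) and shows that this single change makes no clear difference here. No measured evidence explains why 3-methoxyphenyl and 4-fluorophenyl separate in this way.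

As far as these compounds go, all four compounds carry a substituted phenyl group at this place on the same shared core, so it remains open whether an amine or a carboxylic acid on that phenyl group would move the number further in either direction. From the compounds shown here alone, it is also open whether a longer chain between this phenyl group and the ester carbonyl would matter more than the choice of group on the ring.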